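Removing the hydroxy group from compound 3

The source may hold more compounds than are shown below. What is called first, only, known or untested is meant among the compounds shown, and "the series" means these compounds.

Measured in a functional assay on cells (Renal cancer cell line, Homo sapiens) for cytotoxicity, read by sulforhodamine B assay, with a stated time of 48 h; on this read-out lower numbers stand for stronger inhibition of growth and higher numbers for weaker inhibition of growth:
- compound 1 `COc1nc2sc(C)cn2c1C=C1C(=O)N(C)c2ccccc21`: 70600 nM
- compound 2 `COc1ccc2c(c1)/C(=C\c1c(OC)nc3sc(C)cn13)C(=O)N2`: 61800 nM
- compound 3 `COc1nc2sc(C)cn2c1/C=C1/C(=O)Nc2ccc(O)cc21`: 79400 nM

Compound 3, at 79400 nM, lies within the usual scatter of both other compounds, so these three values cannot be told apart. The next compound is compound 4 `COc1nc2sc(C)cn2c1/C=C1/C(=O)Nc2ccccc21`, which has hydrogen in place of hydroxy on an aromatic carbon.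

Two measurements bear on this change. Swapping the group on that same carbon gave a 1.3-fold higher number from compound 2 to compound 3 (0.11 log units; within the scatter), so that swap left the number within the scatter. Compound 1 also has hydrogen on that carbon, though it carries an extra methyl compared with compound 4, and compound 1 gives 70600 nM. Neither measurement points to a real shift, so no step beyond the scatter is expected in this assay.

The expected result is a 1.1-fold lower number from compound 3 to compound 4 (0.05 log units; within the scatter).

Compound 4 is estimated at 70000 nM, with an expected range of 40000 nM to 110000 nM.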

Compound 4, concentration for total growth inhibition: 67600 nM
Compound 4: the middle estimate sits 1.0-fold (0.02 log units) above what was measured; measured number inside the range.
By their numbers in this assay, from the lowest: compounds 2, 4, 1 and 3 (each within the scatter of the next).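

Swapping hydroxy for hydrogen on this aromatic carbon gives, in this assay, a 1.2-fold lower number from compound 3 to compound 4 (0.07 log units; within the scatter). Swapping methoxy for hydrogen on the same carbon gives a 1.1-fold higher number from compound 2 to compound 4 (0.04 log units; within the scatter). The earlier compounds compared only hydroxy with methoxy; with hydrogen now measured as well, the unsubstituted carbon also cannot be told apart from either group, so among these three compounds, the group on this carbon makes no readable difference to the concentration needed for total growth inhibition. Nothing available here offers an explanation for this lack of difference.

Still open, going by these compounds, is whether a different group on this carbon, such as an amine, a carboxylic acid, a chlorine atom or a longer chain, would move the number beyond the scatter. These compounds also leave open whether changes elsewhere on the shared core would do so.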